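A few compounds are considered here, and "the series" means these few. Any claim that something is new, unique, unknown or untested is made for them only; others in the source may bear on it.

Of the compounds shown here, three have so far been measured in an ADME assay on microsomes from liver for inhibition of cytochrome P450 2B1 (Rattus norvegicus); a higher number here means a weaker inhibitor, a lower number a stronger inhibitor. Compound 1 `c1ccc2cc(Cc3nc4ccccc4[nH]3)ccc2c1` gives 18200 nM in this assay, and compound 2 `Clc1ccc(Cc2nc3ccccc3[nH]2)c(Cl)c1` gives 15100 nM. Compound 3 `CCCc1nc2cc(C)c(C)cc2[nH]1` gives 110000 nM in this assay and stands highest of the three numbers, separated from both compound 1 and compound 2 by gaps that lie beyond the usual scatter; compound 1 is its nearest neighbour and compound 2 the furthest.

The step from compound 3 to compound 4 `CCCCCCCc1nc2cc(C)c(C)cc2[nH]1` is butyl in place of hydrogen on a saturated chain carbon, three bonds along the chain from an aromatic carbon. Among the measured compounds shown here, no measured pair differs in just this way, so nothing among the measured compounds sets the size of this step directly. What the numbers do show is that compound 3, with its short chain, gives the weakest inhibition of the three, while compound 1 and compound 2, which carry larger groups on the shared core, give lower numbers in this assay. On that basis the longer chain of compound 4 is expected to move the number downward, by an estimated step of a 4.4-fold lower number from compound 3 to compound 4 (0.64 log units; beyond the scatter), beyond the scatter. Compound 4 is therefore estimated at about 25000 nM in this assay, within an expected range from 6000 nM to 90000 nM.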

Compound 4, half-maximal inhibitory concentration in the cytochrome P450 2B1 assay: 44700 nM
For compound 4 the middle estimate is 1.8-fold (0.25 log units) below the measured one; measured number inside the range.
By their numbers in the cytochrome P450 2B1 assay, from the lowest: compounds 2 and 1 (each within the scatter of the next); then compound 4; then compound 3.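

Among the compounds shown here, compounds 3 and 4 form the first measured pair that differs in one place, and in the cytochrome P450 2B1 assay butyl on this saturated chain carbon, three bonds along the chain from an aromatic carbon, gives a 2.5-fold lower number from compound 3 to compound 4 (0.39 log units; beyond the scatter), a modest step but one beyond the scatter. In a physicochemical assay for lipophilicity (a lower number here means a more polar compound, a higher number a more lipophilic compound), compound 3 gives 3.4 and compound 4 gives 5.4. The same change makes compound 4 more lipophilic than compound 3 in the physicochemical assay: the measured partition coefficient of compound 3, 3.4, and of compound 4, 5.4, a number 2.00 log units higher (beyond the scatter) Taken together, this pair couples a large rise in the partition coefficient with only a modest fall in the number for enzyme inhibition.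

A single pair cannot show whether the number keeps falling with a longer chain such as decyl, or whether it follows the partition coefficient at all. It also leaves open what a branched chain, an amine or a carboxylic acid in place of butyl would do to either read-out.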